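Chloro to methyl on the same ring: compound 1 to compound 4

The source may hold more compounds than are shown below. What is called first, only, known or untested is meant among the compounds shown, and "the series" means these compounds.

Compound 1 `COc1cc2ncnc(NNC(=S)NC(=O)c3ccc(Cl)cc3)c2cc1OC` gives 7530 nM in a functional assay on CNE-2 cells (Homo sapiens) for cytotoxicity, read by MTT assay, with a stated time of 72 h (on this read-out higher numbers stand for weaker inhibition and lower numbers for stronger inhibition), the lowest of the three numbers shown. Compound 2 `COc1cc2ncnc(NNC(=S)NC(=O)c3ccccc3F)c2cc1OC` gives 12700 nM and compound 3 `COc1ccccc1C(=O)NC(=S)NNc1ncnc2ccccc12` gives 15700 nM. For the measured compounds named here, the step of a 1.7-fold higher number from compound 1 to compound 2 (0.23 log units; within the scatter) lies within the scatter, while the gap from compound 1 to compound 3 lies just beyond it; compound 3 differs from compound 1 in more than one place, so no single step is drawn from it. Compound 4 `COc1cc2ncnc(NNC(=S)NC(=O)c3ccc(C)cc3)c2cc1OC` is compound 1 with methyl in place of chloro on an aromatic carbon. Only a 1.7-fold higher number from compound 1 to compound 2 (0.23 log units; within the scatter) bears on this change, as another swap on the same ring, and it was small. The step of a 1.2-fold higher number from compound 1 to compound 4 (0.08 log units; within the scatter) is therefore expected to stay within the scatter. Compound 4 is estimated at 9000 nM, range 4500 nM to 18000 nM.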

Compound 4, half-maximal inhibitory concentration: 33300 nM
Compound 4: middle estimate off by 3.7-fold (0.57 log units), on the low side, outside the stated range (above it).
By their numbers in this assay, from the lowest: compounds 1, 2 and 3 (each within the scatter of the next, the first and the last beyond it); then compound 4.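

Swapping chloro for methyl, one heavy atom for one, on the aromatic carbon para to a large group gives a 4.4-fold higher number from compound 1 to compound 4 (0.65 log units; beyond the scatter) in this assay, so this position responds to a change that keeps the heavy-atom count. For the compounds shown here, the 4-methylphenyl compound also separates from the 2-fluorophenyl one, with a 2.6-fold higher number from compound 2 to compound 4 (0.42 log units; beyond the scatter), a gap that the earlier compounds did not reach. No measurement shown accounts for the step.

Open, going by these compounds, is whether bromo, trifluoromethyl or an amine at this position would sit nearer compound 1 or compound 4. Also open, on these data alone, is whether the same swap gives a similar step on the core of compound 3.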